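Chloro for Bromo on the Thioether Aryl Ring

The compounds below may be only part of what the source reports. "The series", "measured", "known", "first", "only" and "open" are said of these compounds alone.

Three compounds sharing one nucleoside core were measured in an assay on isolated protein for binding affinity to Equilibrative nucleoside transporter 1 (Homo sapiens); on this read-out lower numbers stand for stronger inhibition and higher numbers for weaker inhibition. Compound 1 `OC[C@H]1O[C@@H](n2cnc3c(OCc4ccccc4)ncnc32)[C@H](O)[C@@H]1O` gives 2090 nM and compound 2 `Cc1cc(C)c(SCc2ncnc3c2ncn3[C@@H]2O[C@H](CO)[C@@H](O)[C@H]2O)c(C)c1` gives 33100 nM. Compound 3 `OC[C@H]1O[C@@H](n2cnc3c(CSc4cccc(Br)c4)ncnc32)[C@H](O)[C@@H]1O` gives 363 nM, the lowest of the three numbers; the step from its nearest neighbour was a 5.8-fold lower number from compound 1 to compound 3 (0.76 log units; beyond the scatter), and the step from the furthest was a 91-fold lower number from compound 2 to compound 3 (1.96 log units; beyond the scatter). Compound 4 `OC[C@H]1O[C@@H](n2cnc3c(CSc4cccc(Cl)c4)ncnc32)[C@H](O)[C@@H]1O` differs from compound 3 by chloro in place of bromo on an aromatic carbon. Among the measured compounds shown here, neither measured step exchanges one halogen for another; both alter larger parts of the side chain, so no measured step bears directly on this change. The expected step is therefore a 1.4-fold higher number from compound 3 to compound 4 (0.14 log units; within the scatter), not beyond the scatter. In this assay compound 4 is estimated at 500 nM, with a range from 200 nM to 1500 nM.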

Compound 4, half-maximal inhibitory concentration: 282 nM
The estimate for compound 4 lay 1.8-fold (0.25 log units) above the measured number; the range from low to high includes it.
By their numbers in this assay, from the lowest: compounds 4 and 3 (each within the scatter of the next); then compound 1; then compound 2.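

Chloro in place of bromo on this aromatic carbon gives a 1.3-fold lower number from compound 3 to compound 4 (0.11 log units; within the scatter) in this assay, so the two halogens are not told apart at this place. The 3-chlorophenyl compound keeps the standing of the 3-bromophenyl one, with a 120-fold lower number from compound 2 to compound 4 (2.07 log units; beyond the scatter) and a 7.4-fold lower number from compound 1 to compound 4 (0.87 log units; beyond the scatter) as the steps from the other two compounds. No measurement shown accounts for this result. The compounds shown leave open how fluoro or iodo would read at this place, and whether a methoxy group, an amine or a carboxylic acid there would stay within the scatter of chloro.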